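This account rests on a few compounds, and the source may have more. Where it says the series, first, only, none or still open, it means among the compounds named here.

In a functional assay on A549 cells (Homo sapiens) for inhibition, read by MTT assay, with a stated time of 72 h; a higher number here means a weaker inhibitor, a lower number a stronger inhibitor:
Compound 1 `COc1cc2c(Oc3ccc(NC(=O)c4nn(-c5ccccc5)cc(C)c4=O)cc3)ccnc2cc1OCCCCCCC(=O)NO`: 420 nM
Compound 2 `COc1cc2c(Oc3ccc(NC(=O)c4nn(-c5ccc(C)cc5C)cc(C)c4=O)cc3)ccnc2cc1OCCCCCCC(=O)NO`: 1840 nM

Compound 2 holds the higher of the two numbers, which makes it the weaker inhibitor. Compound 3 `COc1cc2c(Oc3ccc(NC(=O)c4nn(-c5cccc(C(F)(F)F)c5)cc(C)c4=O)cc3)ccnc2cc1OCCCCCCC(=O)NO` has 3-(trifluoromethyl)phenyl in place of 2,4-dimethylphenyl on an aromatic nitrogen. Among the measured compounds shown here, only one measured step bears on this change: a 4.4-fold higher number from compound 1 to compound 2 (0.64 log units; beyond the scatter), a modest one. For the measured compounds named here, no measured compound carries trifluoromethyl, so that step supports only a modest expected return in this assay part of the way toward compound 1. The expected change is a 2.3-fold lower number from compound 2 to compound 3 (0.36 log units; beyond the scatter). Compound 3 is estimated at 800 nM, with an expected range of 300 nM to 2200 nM.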

Compound 3, half-maximal inhibitory concentration: 780 nM
Compound 3: the middle estimate sits 1.0-fold (0.01 log units) above what was measured, and the stated range covers the measured number.
By their numbers in this assay, from the lowest: compounds 1 and 3 (each within the scatter of the next); then compound 2.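

In this assay, the loss seen with 2,4-dimethylphenyl on the aromatic nitrogen does not extend to every substituted phenyl: 3-(trifluoromethyl)phenyl recovers much of it (a 2.4-fold lower number from compound 2 to compound 3 (0.37 log units; beyond the scatter)). Against the plain phenyl, the added trifluoromethyl stays within the scatter (a 1.9-fold higher number from compound 1 to compound 3 (0.27 log units; within the scatter)), so this position accepts at least one substituted ring without a measurable loss. Nothing shown explains the difference between the two substituted rings. Still open, on these data alone, is whether a single methyl, a chlorine or a methoxy group on this phenyl would track with compound 2 or compound 3, and how a pyridyl ring would fare here.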